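Thiophene for methylsulfonylphenyl in a weakly active series

A few compounds are considered here, and "the series" means these few. Any claim that something is new, unique, unknown or untested is made for them only; others in the source may bear on it.

Three measured compounds share one core. Compound 1 `Cn1c(=O)c(=O)n(C2CCCC2)c2nc(N/N=C/c3ccc(S(C)(=O)=O)cc3)ncc21` gives 26600 nM in a functional assay on PC-3 cells (Homo sapiens) for antiproliferative activity, read by MTT assay (on this read-out higher numbers stand for weaker inhibition and lower numbers for stronger inhibition), the highest of the three numbers, though only narrowly; compound 2 `COc1cccc(/C=N/Nc2ncc3c(n2)n(C2CCCC2)c(=O)c(=O)n3C)c1` gives 20700 nM and compound 3 `Cn1c(=O)c(=O)n(C2CCCC2)c2nc(N/N=C/c3cc(C(F)(F)F)c(O)c(C(F)(F)F)c3)ncc21` gives 17700 nM, both within the scatter of compound 1. Compound 4 `Cn1c(=O)c(=O)n(C2CCCC2)c2nc(N/N=C/c3cccs3)ncc21` has not yet been measured; it differs from compound 1 by thiophen-2-yl in place of 4-(methylsulfonyl)phenyl on a carbon with a double bond to nitrogen. Going by the values given here, the only measured step at the same place, a 1.3-fold lower number from compound 1 to compound 2 (0.11 log units; within the scatter), stayed within the scatter, and no other step bears on this change. The step expected is therefore small, a 1.2-fold lower number from compound 1 to compound 4 (0.08 log units; within the scatter), with no direction beyond the scatter. Compound 4 is estimated at 22000 nM, with a range from 8000 nM to 60000 nM.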

Compound 4, half-maximal inhibitory concentration: 75600 nM
The estimate for compound 4 lay 3.4-fold (0.54 log units) below the measured number, and the stated range ends below it.
By their numbers in this assay, from the lowest: compounds 3, 2 and 1 (each within the scatter of the next); then compound 4.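

In this assay, going by these compounds alone, this position turns out not to be indifferent to its group: thiophen-2-yl gives a 2.8-fold higher number from compound 1 to compound 4 (0.45 log units; beyond the scatter) and a 3.7-fold higher number from compound 2 to compound 4 (0.56 log units; beyond the scatter), whereas the one earlier step at this place stayed within the scatter. Among the compounds shown, the one five-membered aromatic ring at this place goes with the highest number, but a single compound makes no pattern. Nothing measured here accounts for this step. The compounds shown leave open whether a plain phenyl or a furan-2-yl on this carbon would give a number like that of compound 1 or that of compound 4.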